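This account rests on a few compounds, and the source may have more. Where it says the series, first, only, none or still open, it means among the compounds named here.

In an in vitro ADME assay on microsomes from liver (Mus musculus, strain CD1) for metabolic stability, using NADPH, with a stated time of 10 min, tested at 0.5 uM (on this read-out lower numbers stand for a shorter-lived compound and higher numbers for a longer-lived compound), compound 1 `COc1ccc(Nc2ncc3ccc(-c4ccccc4OC)n3n2)cc1` gives 0.117 h, and compound 2 `COc1ccccc1-c1ccc2cnc(Nc3ccc(S(=O)(=O)N(C)C)cc3)nn12` gives 0.0833 h. Within the data shown here, the only measured step, a 1.4-fold lower number from compound 1 to compound 2 (0.15 log units; within the scatter), stays within the scatter, so compound 2 and compound 1 sit within the scatter of each other and neither can be ranked above the other. Compound 3 `COc1ccccc1-c1ccc2cnc(Nc3ccc(N4CCN(C[C@H](C)O)CC4)cc3)nn12` differs from compound 2 by 4-(2-hydroxypropyl)piperazin-1-yl in place of dimethylsulfamoyl on an aromatic carbon. Among the measured compounds shown here, no measured step bears on this change; the one step swapped a different group. With nothing pointing either way, compound 3 is expected to stay near compound 2, at an estimated 0.1 h with a range from 0.04 h to 0.25 h. The expected step is a 1.2-fold higher number from compound 2 to compound 3 (0.08 log units; within the scatter), within the scatter.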

Compound 3, half-life: > 0.666 h
Compound 3 gave a limit, no number (the forecaster's own chance of this, stated with the estimate: 5%); at least 6.6-fold (0.82 log units) between middle value and limit.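

Methoxy and dimethylsulfamoyl on this aromatic carbon had stayed within the scatter of each other, but in this assay the new group gives a clear change: an at least 7.9-fold higher number from compound 2 to compound 3 (0.90 log units; beyond the scatter), and an at least 5.6-fold higher number from compound 1 to compound 3 (0.75 log units; beyond the scatter). So this position can shift the read-out, and here 4-(2-hydroxypropyl)piperazin-1-yl goes with a longer-lived compound. The reading for compound 3 is a limit, not a number: the limit of > 0.666 h in this assay, at which 1 of the 3 values shown sits.

Going by these compounds, how far compound 3 lies past that limit stays open. Also open, on these data alone, is whether a plain piperazine without the hydroxypropyl chain, or a morpholine, would behave the same on this carbon.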